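The source may report more compounds than this note shows. Statements on the series, on what has been measured and on what is new or still open speak of the compounds shown alone.

Working notes on the series in a functional assay on MCF7 cells (Homo sapiens) for inhibition, read by MTT assay, with a stated time of 96 h; on this read-out higher numbers stand for weaker inhibition of growth and lower numbers for stronger inhibition of growth. Of the compounds shown here, two have numbers so far. Compound 1 (`O=C(NCCCCCCSSCCCCCCNC(=O)c1cc(-c2ccncc2)n[nH]1)c1cc(-c2ccncc2)n[nH]1`) gives 7150 nM. Among the measured compounds shown here, compound 2 (`O=C(OCc1ccccc1)SCCCCCCNC(=O)c1cc(-c2ccncc2)n[nH]1`) gives 8370 nM, and these two values lie within the scatter of each other, so compound 2 stands level with the only other measured compound. Compound 3 (`CC(C)C(=O)SCCCCCCNC(=O)c1cc(-c2ccncc2)n[nH]1`) has no number yet. Its difference from compound 2 is isopropyl in place of benzyloxy on a carbonyl carbon, or, cut one bond further out, benzyloxycarbonyl to isopropylcarbonyl. For the measured compounds named here, no measured pair differs in one place, so the data offer no direct precedent for the size of this change. With nothing pointing to a large move, only a small shift is expected in this assay, leaning towards stronger inhibition of growth and possibly staying within the scatter. The expected change is a 1.5-fold lower number from compound 2 to compound 3 (0.18 log units; within the scatter). Compound 3 is estimated at 5500 nM, with an expected range of 2200 nM to 13000 nM.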

Compound 3, concentration for 50% growth inhibition: 15200 nM
For compound 3 the middle estimate is 2.8-fold (0.44 log units) below the measured one; the whole stated range lies below it.
By their numbers in this assay, from the lowest: compounds 1, 2 and 3 (each within the scatter of the next, the first and the last beyond it).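

In this assay, the series now has one readable step at this position: on a carbonyl carbon whose other neighbours are sulfur, isopropyl in place of benzyloxy gives a 1.8-fold higher number from compound 2 to compound 3 (0.26 log units; within the scatter) and so stays within the scatter. The change takes out 8 heavy atoms, including one six-membered aromatic ring of carbon only and 1 hydrogen-bond acceptor, and puts in 3 heavy atoms with no ring and no hydrogen-bond acceptor, yet this read-out does not separate the two groups. No measurement shown bears on the reason for this outcome, and a single pair sets no trend for the position.

The compounds shown leave open whether any group on this carbonyl carbon can move the number beyond the scatter, for example a methyl, a phenyl, an amine or a group carrying a carboxylic acid. They also leave open whether a longer chain in place of the isopropyl, or a benzyloxy replacement made with the rest of the molecule held constant, would give a step of a different size.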